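The source may hold more compounds than are shown below. What is called first, only, known or untested is meant among the compounds shown, and "the series" means these compounds.

Measured compounds and values:
- compound 1, `O=C(O)c1cc(-n2c(-c3ccccc3)cc3c2CCCC3)ccc1S`: 50%
- compound 2, `O=C(O)c1cc(-n2c(-c3ccccc3)cc3c2CCCC3)cc(Br)c1O`: 0%
- compound 3, `COc1cccc(-c2cc3c(n2-c2ccc(O)c(C(=O)O)c2)CCCC3)c1`: 20%

In a functional assay on the whole organism (strain Wistar) for inhibition, with Rattus norvegicus as the target, read by paw edema, with stated times of 30 min and 3 h, at a dose of 200 mg/kg by the oral route (a higher number here means more inhibition at the dose given (going by the name of the read-out), a lower number less inhibition), compound 1 gives 50%, compound 2 gives 0% and compound 3 gives 20%. Compound 3 stands second highest of the three. Its nearest neighbour is compound 2, whose number lies lower by a gap beyond the usual scatter; its furthest is compound 1, whose number lies higher, again beyond the scatter. Among the measured compounds shown here, compound 2 and compound 3 differ in more than one place, as do compound 1 and compound 3, so no single step between the measured compounds can be read out; only the values themselves stand.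

The next compound, compound 4, has the structure `O=C(O)c1cc(-n2c(-c3ccc(F)cc3)cc3c2CCCC3)ccc1O`. It differs from compound 3 as follows: 4-fluorophenyl in place of 3-methoxyphenyl on an aromatic carbon

For the measured compounds named here, no step of this sort has been measured here, so the expectation rests on the value of compound 3 alone. Since compound 3 gives 20%, the step is expected to be small, in either direction, and likely to remain within the scatter, which is what a number 5 percentage points higher from compound 3 to compound 4 (within the scatter) expresses. Compound 4 is therefore estimated at 25% in this assay, with a range from 0% to 55%.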

Compound 4, a percentage reported as inhibition, in the whole organism at one dose (the size of the read-out at that dose, not a potency): >= 60%
Compound 4 gave a limit, no number (the forecaster's own chance of this, stated with the estimate: 5%); middle value at least 35 percentage points away from the limit.
By their numbers in this assay, from the lowest: compound 2; then compound 3; then compound 1. At a limit, above all of these: compound 4.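

In this assay compound 4 gives >= 60%, which is a limit of the assay and not a number. The earlier compounds shown here offered no single-place step, whereas putting 4-fluorophenyl in place of 3-methoxyphenyl on this aromatic carbon, next to the ring nitrogen, gives a number at least 40 percentage points higher from compound 3 to compound 4 (beyond the scatter), so the aromatic group at this position clearly matters. Only a lower bound on the size of this step can be read, and its upper end remains unresolved: the limit of >= 60% in this assay, at which 1 of the 4 values shown sits.

The compounds shown leave open which part of the change carries the step, since the methoxy group leaves and the fluorine enters at different places on the phenyl ring; 4-methoxyphenyl and 3-fluorophenyl at this position would separate the two. Also open, as far as these compounds go, is how far other groups on that phenyl ring, such as a chlorine, an amine or a longer alkoxy chain, would hold the inhibition of paw edema seen with compound 4.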